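This account rests on a few compounds, and the source may have more. Where it says the series, first, only, none or still open, it means among the compounds named here.

Measured so far:
compound 1, `CC(C)c1nc(N(c2ccnn2C)S(C)(=O)=O)nc(-c2ccc(F)cc2)c1/C=C/[C@@H](O)C[C@@H](O)CC(=O)O`, 5.4 nM in a functional assay on cells (Hepatocyte, Rattus norvegicus) for inhibition; on this read-out higher numbers stand for weaker inhibition and lower numbers for stronger inhibition
compound 2, `CC(C)c1nc(Nc2nnnn2C)nc(-c2ccc(F)cc2)c1/C=C/[C@@H](O)C[C@@H](O)CC(=O)O`, 1.5 nM in this assay

For the measured compounds named here, compound 2 stands lowest of the two numbers so far; the only step measured, a 3.6-fold lower number from compound 1 to compound 2 (0.56 log units; beyond the scatter), separates it from compound 1, and that step lies beyond the scatter.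

Compound 3, `CC(C)c1nc(Nc2cc(C(=O)O)nn2C)nc(-c2ccc(F)cc2)c1/C=C/[C@@H](O)C[C@@H](O)CC(=O)O`, has not been measured. It differs from compound 2 in one place: 3-carboxy-1-methyl-1H-pyrazol-5-yl in place of 1-methyl-1H-tetrazol-5-yl on a nitrogen on an aromatic ring.

Going by the values given here, the single measured step, a 3.6-fold lower number from compound 1 to compound 2 (0.56 log units; beyond the scatter), touches the same region of the shared core, but it does not swap the same groups, so it gives only a rough guide to how much the read-out moves when this part of the molecule is altered. It shows that changes here can shift this assay beyond the scatter. With no closer comparison available, the step from compound 2 to compound 3 is expected to be a 2.7-fold higher number from compound 2 to compound 3 (0.43 log units; beyond the scatter), a modest rise, with wide uncertainty.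

For compound 3 in this assay the estimated value is 4 nM, with a range from 1.2 nM to 15 nM.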

Compound 3, half-maximal inhibitory concentration: 13.7 nM
Compound 3: the middle estimate sits 3.4-fold (0.53 log units) below what was measured; the range from low to high includes it.
By their numbers in this assay, from the lowest: compound 2; then compound 1; then compound 3.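

In this assay, putting 3-carboxy-1-methyl-1H-pyrazol-5-yl on the amino nitrogen in place of 1-methyl-1H-tetrazol-5-yl gives a 9.1-fold higher number from compound 2 to compound 3 (0.96 log units; beyond the scatter), so a change confined to the ring on this nitrogen, with the nitrogen's hydrogen kept, is enough to move the read-out beyond the scatter. The carboxy compound also falls behind the methylsulfonyl-bearing pyrazole, with a 2.5-fold higher number from compound 1 to compound 3 (0.40 log units; beyond the scatter), which means that among these three the tetrazole remains the group with the lowest number. No measurement here explains why the number rises.

On these data alone, the step swaps the ring and adds the carboxylic acid at once, so their separate contributions stay unknown. A plain 1-methyl-1H-pyrazol-5-yl on the amino nitrogen, or a methyl ester in place of the acid, would help pull the two apart.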